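A Methyl on the Ring Nitrogen: Expected Shift in Lipophilicity

A few compounds are considered here, and "the series" means these few. Any claim that something is new, unique, unknown or untested is made for them only; others in the source may bear on it.

Compound 1 `Cn1c(NC(=O)c2cccnc2)cc2ccccc21` gives 1.3 in a physicochemical assay for lipophilicity; on this read-out lower numbers stand for lower lipophilicity and higher numbers for higher lipophilicity.
Compound 2 `O=C(Cn1ccccc1=O)Nc1cc2ccccc2[nH]1` gives 0.4.
Compound 3 `COC(=O)c1ccc2c(C(=O)c3ccccc3)cc(C(=O)c3ccccc3)c-2cc1` gives 5.5.

Compound 2 holds the lowest of these three numbers. Compound 1 sits higher by a gap beyond the usual scatter, and compound 3 sits higher still, far beyond it. Compound 4 `Cn1c(NC(=O)Cn2ccccc2=O)cc2ccccc21` has not yet been measured; it differs from compound 2 in a single place: methyl in place of hydrogen on an aromatic nitrogen. For the measured compounds named here, no pair of measured compounds shows this same change, so its size cannot be read from the numbers already in hand. The expectation is a small upward step in this assay, a number 0.40 log units higher from compound 2 to compound 4 (beyond the scatter), not much larger than the scatter. Compound 4 is therefore estimated at 0.8, with a range from 0.4 to 1.3.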

Compound 4, partition coefficient: 1.1
Compound 4: middle estimate off by 0.30 log units, on the low side; low and high end bracket the measured number.
By their numbers in this assay, from the lowest: compound 2; then compounds 4 and 1 (each within the scatter of the next); then compound 3.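

In this assay, methyl in place of hydrogen on an aromatic nitrogen goes with a number 0.70 log units higher from compound 2 to compound 4 (beyond the scatter). For the compounds shown here, this gives the first measured size for this change at this position, where the earlier compounds offered no such pair. Nothing at hand accounts for the size of this step.

As far as these compounds go, it remains open what an ethyl group or a longer chain on this same aromatic nitrogen would do to the number. A single pair also leaves open whether the methyl change would give a similar step on another core.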